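Thiophen-2-yl in place of 4-chlorophenyl in compound 3

The source may report more compounds than this note shows. Statements on the series, on what has been measured and on what is new or still open speak of the compounds shown alone.

Compound 1 `CC(=O)CCSC(=S)NCc1cccnc1` gives 4220 nM
Compound 2 `NC(=O)CCSC(=S)NCc1cccnc1` gives 4630 nM
Compound 3 `S=C(NCc1cccnc1)SCCc1nnc(-c2ccc(Cl)cc2)o1` gives 1980 nM

In a functional assay on MDA-MB-468 cells (Homo sapiens) for cytotoxicity, read by resazurin assay, with a stated time of 72 h (a higher number here means a weaker inhibitor, a lower number a stronger inhibitor), compound 3 has the lowest of the three numbers at 1980 nM and lies beyond the scatter from both compound 1 and compound 2. Compound 4 `S=C(NCc1cccnc1)SCCc1nnc(-c2cccs2)o1` has not yet been measured. It carries thiophen-2-yl in place of 4-chlorophenyl on an aromatic carbon of a five-membered aromatic ring with 2 nitrogen and 1 oxygen thiophen-2-yl in place of 4-chlorophenyl on an aromatic carbon while the rest of compound 3 stays the same. Within the data shown here, no measured step touches this place. Among the measured compounds shown here, the only step available, a 1.1-fold higher number from compound 1 to compound 2 (0.04 log units; within the scatter) in this assay and thus within the scatter, concerns amino in place of methyl on a carbonyl carbon, so it sets no size for this change. Starting from compound 3 at 1980 nM only a small move towards a higher number is expected, probably not beyond the scatter. The estimated step is a 1.4-fold higher number from compound 3 to compound 4 (0.15 log units; within the scatter) in this expectation. For compound 4 the estimated value is 2800 nM with an expected range from 1200 nM to 6500 nM at this stage.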

Compound 4, half-maximal inhibitory concentration: 3410 nM
The estimate for compound 4 lay 1.2-fold (0.09 log units) below the measured number, and the stated range covers the measured number.
By their numbers in this assay, from the lowest: compounds 3, 4, 1 and 2 (each within the scatter of the next, the first and the last beyond it).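

In this assay, among these compounds, thiophen-2-yl in place of 4-chlorophenyl on this aromatic carbon gives a 1.7-fold higher number from compound 3 to compound 4 (0.24 log units; within the scatter), the first step read at this place, as the only earlier step concerned a carbonyl carbon. The change replaces a six-membered aromatic ring of carbon only with a five-membered aromatic ring with 1 hetero atom and removes the chlorine, yet this assay does not separate the two compounds, so this position accepts either group within the scatter. Nothing available explains this outcome.

From the compounds shown here alone, whether an amine or a carboxylic acid on this aromatic carbon would stay close to compound 3 at 1980 nM remains open. Also open, going by these compounds, is whether plain phenyl would separate the loss of the chlorine from the change of ring.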